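The source may hold more compounds than are shown below. What is called first, only, known or untested is meant among the compounds shown, and "the series" means these compounds.

Compound 1 `CN(C)c1ccc(C=C2C(=O)N(c3ccc(Cl)cc3)N(c3ccc(Cl)cc3)C2=O)cc1`: > 128000 nM
Compound 2 `COc1ccc(C=C2C(=O)N(c3ccc(Cl)cc3)N(c3ccc(Cl)cc3)C2=O)cc1`: > 128000 nM
Compound 3 `COc1ccc(C=C2C(=O)N(c3ccc(Cl)cc3)N(c3ccc(Cl)cc3)C2=O)cc1OC`: > 128000 nM

All three results come from a functional assay on ECa-109 cells (Homo sapiens) for cytotoxicity, read by MTT assay, with a stated time of 72 h; on this read-out higher numbers stand for weaker inhibition and lower numbers for stronger inhibition. Compound 3 stands at > 128000 nM, which is a limit and not a number. It shares this position with the other two, as the limit of > 128000 nM in this assay, at which 3 of the 3 values shown sit, shows. Compound 4 `COc1ccccc1C=C1C(=O)N(c2ccc(Cl)cc2)N(c2ccc(Cl)cc2)C1=O` has 2-methoxyphenyl in place of 3,4-dimethoxyphenyl on a double-bonded chain carbon bound to a double-bonded ring carbon. The measured changes that bear most closely on this are a step that the two limits leave unreadable from compound 2 to compound 3 and a step that the two limits leave unreadable from compound 1 to compound 3, with a step that the two limits leave unreadable from compound 1 to compound 2 as a further comparison. None of them offers a size or direction to carry over. The expected outcome is therefore no step beyond the scatter: a number no higher from compound 3 to compound 4 (the limit leaves the size open). For compound 4 the estimated value is 128000 nM, with an expected range from 40000 nM to 200000 nM.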

Compound 4, half-maximal inhibitory concentration: 30400 nM
Compound 4: the middle estimate sits 4.2-fold (0.62 log units) above what was measured; the whole stated range lies above it.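

Among the compounds shown here, compound 4 brings the first readable number at this place on the chain carbon: in this assay, 2-methoxyphenyl gives an at least 4.2-fold lower number from compound 3 to compound 4 (0.62 log units; beyond the scatter), and an at least 4.2-fold lower number from compound 1 to compound 4 (0.62 log units; beyond the scatter). Moving from 4-methoxyphenyl to 2-methoxyphenyl gives an at least 4.2-fold lower number from compound 2 to compound 4 (0.62 log units; beyond the scatter), so the place of a single methoxy on this ring changes the result. The steps among the earlier compounds cannot be read, and each of them is only a limit: the limit of > 128000 nM in this assay, at which 3 of the 4 values shown sit.

Going by these compounds, the true sizes of the new steps stay open. On these data alone, it is also open whether a hydroxyl or an amine in place of the methoxy of 2-methoxyphenyl would give a similar number.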